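Swapping chloro for bromo on the benzyl arm

A few compounds are considered here, and "the series" means these few. Any claim that something is new, unique, unknown or untested is made for them only; others in the source may bear on it.

Of the compounds shown here, three sharing one core have been measured in an assay on isolated protein for inhibition of serine/threonine-protein kinase PAK 4 (Homo sapiens), read by HTRF, with a stated time of 60 min; on this read-out lower numbers stand for stronger inhibition and higher numbers for weaker inhibition. Compound 1 `Cc1cc(Nc2nc(Nc3ccccc3)nc3[nH]ncc23)n[nH]1`, which carries a plain phenyl on the ring nitrogen, gives 5900 nM. Compound 2 `Cc1cc(Nc2nc(NCc3ccccc3F)nc3[nH]ncc23)n[nH]1` gives 389 nM, and compound 3 `Cc1cc(Nc2nc(NCc3ccccc3Cl)nc3[nH]ncc23)n[nH]1` gives 668 nM. Replacing the phenyl with a benzyl that bears a halogen brought the number down clearly: a 15-fold lower number from compound 1 to compound 2 (1.18 log units; beyond the scatter) and an 8.8-fold lower number from compound 1 to compound 3 (0.95 log units; beyond the scatter). Between the two halogens themselves the difference is small, a 1.7-fold higher number from compound 2 to compound 3 (0.23 log units; within the scatter). On the numbers shown compound 3 holds the second highest of the three, though its gap to compound 2 lies within the scatter while its gap to compound 1 lies well beyond it.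

Compound 4 `Cc1cc(Nc2nc(NCc3ccccc3Br)nc3[nH]ncc23)n[nH]1` has not yet been measured. It differs from compound 3 in one place: bromo in place of chloro on an aromatic carbon. Within the data shown here, the only measured step that speaks to this kind of exchange is the move from fluoro to chloro, a 1.7-fold higher number from compound 2 to compound 3 (0.23 log units; within the scatter), which stayed within the scatter. A further move along the halogens is therefore expected to shift the number little, and the step is estimated as a 1.0-fold higher number from compound 3 to compound 4 (0.02 log units; within the scatter), with no direction that rises above the scatter. Compound 4 is expected to give 700 nM, with a range from 300 nM to 1600 nM.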

Compound 4, half-maximal inhibitory concentration: 1090 nM
Compound 4: middle estimate off by 1.6-fold (0.19 log units), on the low side; the range from low to high includes it.
By their numbers in this assay, from the lowest: compounds 2, 3 and 4 (each within the scatter of the next, the first and the last beyond it); then compound 1.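

Bromo in place of chloro on this aromatic carbon, ortho to a large group, stays within the scatter (a 1.6-fold higher number from compound 3 to compound 4 (0.21 log units; within the scatter)), yet the two ends of the halogen series now separate (a 2.8-fold higher number from compound 2 to compound 4 (0.45 log units; beyond the scatter)), the first gap between two halogens at this position to lie beyond the scatter. The benzyl arm with bromo still stays clearly on the low side of the plain phenyl (a 5.4-fold lower number from compound 1 to compound 4 (0.73 log units; beyond the scatter)), so all three halogen-bearing benzyl compounds shown hold an advantage over compound 1, even though the exchange of fluoro for bromo gives part of it back. Nothing available here explains why fluoro and bromo differ at this position.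

Still open, on these data alone, is what the halogen itself contributes: a plain benzyl would show the arm without it, while a methyl, methoxy or nitrile in the same place would show whether anything other than a halogen is accepted there. Also open, as far as these compounds go, is how the number responds to a longer chain, such as 2-phenylethyl, on the same nitrogen, or to the same halogens placed elsewhere on the ring.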